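Adding a 4-methoxyphenyl to compound 1

This account rests on a few compounds, and the source may have more. Where it says the series, first, only, none or still open, it means among the compounds named here.

Measured compounds:
compound 1, `CC(C)(C)Cc1csc(N)c1C(=O)c1ccc(Cl)cc1`, gives 1%
compound 2, `CC(C)(C)Cc1c(Br)sc(N)c1C(=O)c1cccc(C(F)(F)F)c1`, gives 1%

In an assay on CHO cells for displacement of a labelled ligand from adenosine receptor A1 (Homo sapiens), read by scintillation counting, tested at 10 uM (a higher number here means more inhibition at the concentration tested (going by the name of the read-out), a lower number less inhibition), compound 1 gives 1%. Compound 2 in this assay gives 1%, so the two values lie level with each other within the usual scatter, and both compounds show almost no displacement of the labelled ligand at the concentration tested. Compound 2 carries a bromine on the ring carbon next to the ring sulfur, yet its value differs in no way that can be told apart from that of compound 1.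

Compound 3, `COc1ccc(-c2sc(N)c(C(=O)c3ccc(Cl)cc3)c2CC(C)(C)C)cc1`, has not yet been measured. It differs from compound 1 as follows: 4-methoxyphenyl in place of hydrogen on an aromatic carbon. For the measured compounds named here, no step between measured compounds that changes one place alone is available for guidance. Given that compound 2 gives 1% with a different group at the same place, the step from compound 1 to compound 3 is expected to be small, at most a modest rise, with a number 5 percentage points higher from compound 1 to compound 3 (within the scatter) as the estimated step. Compound 3 is therefore expected to give about 6%, within a range from 0% to 22%.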

Compound 3, a percentage reported as inhibition, at one concentration (the size of the read-out at that concentration, not a potency): 1%
Estimate against measurement, compound 3: 5 percentage points above; low and high end bracket the measured number.
By their numbers in this assay, from the lowest: compounds 1, 2 and 3 (each within the scatter of the next).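

Measured in this assay, putting 4-methoxyphenyl in place of hydrogen on the aromatic carbon next to the ring sulfur gives no change at the digits printed from compound 1 to compound 3 (within the scatter). For the compounds shown here, this is the first step here that changes this one place alone, since compound 2 also differs from compound 1 on the other aromatic ring, so its value could not speak for this position by itself. Even a group this large, with a six-membered aromatic ring of carbon only and a methoxy end, does not lift the value from near the bottom of the scale, although with values this low a loss could hardly be seen, and no further measurement bears on why the value stays where it is.

The compounds shown leave open whether any group at this place can bring real displacement of the labelled ligand, for instance an amine or a carboxylic acid, or a small ring carrying a basic nitrogen such as piperidine. They also leave open whether 4-methoxyphenyl would have an effect on a related compound that starts from a clearly higher value.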